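Swapping One Aromatic Group in a Well-Tolerated Pair

This account rests on a few compounds, and the source may have more. Where it says the series, first, only, none or still open, it means among the compounds named here.

Compound 1 `CN1CCN(CCNCc2cn(-c3ccc(F)cc3F)nc2Cc2ccccc2)CC1` gives > 20000 nM in an ADME assay on Huh-7 cells (Homo sapiens) for cytotoxicity (a lower number here means that less compound is tolerated, a higher number that more compound is tolerated), which is a limit of the assay rather than a number.
Compound 2 `Cc1ccccc1-c1nn(-c2ccccc2Cl)cc1CNCCN1CCN(C)CC1` gives > 20000 nM in this assay, again a limit and not a number.

Going by the values given here, compound 2 therefore stands at the limit itself, and the one other value shown sits at the same limit (the limit of > 20000 nM in this assay, at which 2 of the 2 values shown sit). Among the compounds with values here, no step between measured compounds can be read from two limits, so nothing here tells how large a change in this assay a structural change of this kind brings.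

Compound 3 `Cc1ccccc1-c1nn(-c2cccc(C(F)(F)F)c2)cc1CNCCN1CCN(C)CC1` has not yet been measured. It differs from compound 2 in one place (3-(trifluoromethyl)phenyl in place of 2-chlorophenyl on an aromatic nitrogen).

With both known values at the limit, the expected step that the limit leaves unreadable from compound 2 to compound 3 is none beyond the scatter. Compound 3 is accordingly estimated at 25000 nM, with a range from 8000 nM to 80000 nM, and the assay is expected most often to report only its limit again.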

Compound 3, half-maximal cytotoxic concentration: 18000 nM
The estimate for compound 3 lay 1.4-fold (0.14 log units) above the measured number; the measured number falls inside the stated range.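

In this assay, compound 3 gives 18000 nM, the first actual number among the compounds shown, so this position on the aromatic nitrogen can now be read against a value. Putting 3-(trifluoromethyl)phenyl in place of 2-chlorophenyl brings an at least 1.1-fold lower number from compound 2 to compound 3 (0.04 log units; that floor lies within the scatter), so this change cannot yet be called a real loss of tolerance. That step is only a floor, and its true size stays hidden at the limit that still holds most of the values shown: the limit of > 20000 nM in this assay, at which 2 of the 3 values shown sit.

The change alters both the group on the phenyl ring and where it sits on that ring, so the two contributions cannot be separated here. Also open, going by these compounds, is how this number would respond to a carboxylic acid or a primary amine on that phenyl ring.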